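The compounds below may be only part of what the source reports. "The series", "measured", "known", "first", "only" and "open" are said of these compounds alone.

Within the data shown here, compound 2 `CN1C(=S)[C@@H](NC(=O)c2nc(Cc3ccccc3)n(CCCC(F)(F)F)n2)COc2ccccc21` gives 2380 nM in a functional assay on HT-29 cells (Homo sapiens) for inhibition, read by luminescence and CellTiter-Glo, with a stated time of 24 h (a higher number here means that more compound is needed for the effect, a lower number that less compound is needed), and stands second highest of the three numbers measured so far: compound 3 `CN1C(=S)[C@@H](NC(=O)c2nc(Cc3ccccc3)n(CC3COC3)n2)COc2ccccc21` gives 2830 nM in this assay, while compound 1 `CN1C(=S)[C@@H](NC(=O)c2nc(Cc3ccccc3)n(CCCO)n2)COc2ccccc21` gives 209 nM in this assay. Compound 4 `Cc1cnc(-n2nc(C(=O)N[C@H]3COc4ccccc4N(C)C3=S)nc2Cc2ccccc2)nc1` differs from compound 2 by 5-methylpyrimidin-2-yl in place of 4,4,4-trifluorobutyl on an aromatic nitrogen. Among the measured compounds shown here, two measured steps bear on this position: an 11-fold higher number from compound 1 to compound 2 (1.06 log units; beyond the scatter) was large, whereas a 1.2-fold higher number from compound 2 to compound 3 (0.08 log units; within the scatter) stayed within the scatter. For the measured compounds named here, no measured step places an aromatic ring on this nitrogen, so the direction is uncertain, but a lower number than that of compound 2 is plausible because compound 1 gives 209 nM in this assay. Compound 4 is therefore expected to give 800 nM, in a range from 150 nM to 4000 nM, which corresponds to an expected 3.0-fold lower number from compound 2 to compound 4 (0.47 log units; beyond the scatter).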

Compound 4, half-maximal effective concentration: 1950 nM
Beside the measured number, compound 4's estimate is 2.4-fold (0.39 log units) below it; the range from low to high includes it.
By their numbers in this assay, from the lowest: compound 1; then compounds 4, 2 and 3 (each within the scatter of the next).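

In this assay the aromatic ring 5-methylpyrimidin-2-yl on this aromatic nitrogen matches the groups without a hydroxy: a 1.2-fold lower number from compound 2 to compound 4 (0.09 log units; within the scatter) and a 1.5-fold lower number from compound 3 to compound 4 (0.16 log units; within the scatter) both stay within the scatter. Set against the 3-hydroxypropyl group, the same ring gives a 9.3-fold higher number from compound 1 to compound 4 (0.97 log units; beyond the scatter) and so, of these four compounds, only compound 1 stands apart. No evidence on hand accounts for this. Still open, as far as these compounds go, is whether a hydroxy group on a longer chain, or an amine or a carboxylic acid at the end of the chain, would match compound 1.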